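Swapping an aromatic substituent on an indole-type serotonin ligand

The source may hold more compounds than are shown below. What is called first, only, known or untested is meant among the compounds shown, and "the series" means these compounds.

Of the compounds shown here, two have been tested so far in an assay on HEK293 cells for binding affinity to 5-hydroxytryptamine receptor 7 (Homo sapiens), read by radioligand binding; on this read-out higher numbers stand for weaker inhibition and lower numbers for stronger inhibition. Compound 1 `Brc1ccc2ccn(CCN3CCCN4CCCCC4C3)c2c1` gives 3 nM in this assay. Compound 2 `CN1CCCN(CCn2ccc3ccc(C(F)(F)F)cc32)CC1` gives 23 nM in this assay, the higher of the two numbers, and its number lies well beyond the usual scatter from that of compound 1. The two compounds differ in more than one place, so the gap between them cannot be tied to any single part of the structure.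

Compound 3 `C#Cc1ccc2ccn(CCN3CCCN(C)CC3)c2c1` has not yet been measured. It differs from compound 2 in one place only: ethynyl in place of trifluoromethyl on an aromatic carbon. The change keeps the rest of compound 2 intact, including the amine-bearing side chain.

Going by the values given here, no measured pair in this set shows what this particular swap does, so the expectation rests on compound 2 alone. The step from compound 2 to compound 3 in this assay is expected to be small, a 1.3-fold lower number from compound 2 to compound 3 (0.11 log units; within the scatter), with no clear direction beyond the scatter. For compound 3 the estimated value in this assay is therefore 18 nM, with a likely range from 5 nM to 60 nM.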

Compound 3, inhibition constant: 140 nM
Estimate against measurement, compound 3: 7.8-fold (0.89 log units) below; measured number outside the range, above it.
By their numbers in this assay, from the lowest: compound 1; then compound 2; then compound 3.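

In this assay, going by these compounds alone, this is the first change in the set confined to one place, so a shift can now be tied to a single group: putting ethynyl in place of trifluoromethyl on this aromatic carbon gives a 6.1-fold higher number from compound 2 to compound 3 (0.78 log units; beyond the scatter), with the amine-bearing side chain and the rest of the structure unchanged. The result shows that the group on this carbon matters for the number in this assay, even though the two groups are alike in the simple counts, with 0 hydrogen-bond donors, 0 hydrogen-bond acceptors, no ring and no net charge on either side. The compounds shown offer no measurement that accounts for the shift.

On these data alone, with only these two groups compared at this carbon, it remains open whether trifluoromethyl is unusually good here or ethynyl unusually poor, and a nitrile or a methoxy group at the same place would help to separate those two readings. As far as these compounds go, it also remains open whether the same swap would shift the number by a similar amount on the different amine side chain of compound 1.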